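Relocating the Chlorine on the Aryl Ring of Compound 1

The compounds below may be only part of what the source reports. "The series", "measured", "known", "first", "only" and "open" are said of these compounds alone.

Compound 1 `O=S(=O)(c1ccc(F)c(Cl)c1)c1cnc2c(F)cccc2c1-c1cccc(Cl)c1` — 0.18 mL/min
Compound 2 `O=S(=O)(c1cc(F)cc(F)c1)c1cnc2c(F)cccc2c1-c1cccc(Cl)c1` — 0.64 mL/min
Compound 3 `O=S(=O)(c1cccc(F)c1)c1cnc2c(F)cccc2c1-c1cccc(Cl)c1` — 0.56 mL/min

In an ADME assay on microsomes from liver (Homo sapiens) for metabolic stability, tested at 2.5 uM (a lower number here means slower removal, a higher number faster removal of the compound), compound 1 gives 0.18 mL/min, the lowest of the three numbers. Compound 3 gives 0.56 mL/min, and compound 2 gives 0.64 mL/min. The steps among the measured compounds are a 3.1-fold higher number from compound 1 to compound 3 (0.49 log units; beyond the scatter) and a 3.6-fold higher number from compound 1 to compound 2 (0.55 log units; beyond the scatter), while the step of a 1.1-fold lower number from compound 2 to compound 3 (0.06 log units; within the scatter) stays within the scatter. All three of these steps change the ring on the sulfonyl sulfur and leave the rest of the shared core untouched.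

Compound 4 `O=S(=O)(c1ccc(F)c(Cl)c1)c1cnc2c(F)cccc2c1-c1ccc(Cl)cc1` departs from compound 1 at a different site: 4-chlorophenyl in place of 3-chlorophenyl on an aromatic carbon. For the measured compounds named here, none of the measured steps alters this ring, so they do not bear directly on the change; they only show that this series can move by modest amounts when one aryl ring is varied. With no closer guide, the expectation for compound 4 rests on compound 1 and its value 0.18 mL/min, and the step is estimated as a 1.2-fold higher number from compound 1 to compound 4 (0.09 log units; within the scatter), most likely not beyond the scatter. Compound 4 is therefore expected to give about 0.22 mL/min in this assay, with a range from 0.09 mL/min to 0.55 mL/min.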

Compound 4, intrinsic clearance in a liver preparation (reported as CLH), per the amount of preparation that the assay uses: 0.01 mL/min
Estimate against measurement, compound 4: 22-fold (1.34 log units) above; measured number below the stated range.
By their numbers in this assay, from the lowest: compound 4; then compound 1; then compounds 3 and 2 (each within the scatter of the next).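

In this assay, for the compounds shown here, the ring on this aromatic carbon proves to be a far more sensitive point of the series than the earlier compounds could show: an 18-fold lower number from compound 1 to compound 4 (1.26 log units; beyond the scatter) is a large step, whereas the changes on the sulfonyl sulfur gave modest ones, such as a 3.1-fold higher number from compound 1 to compound 3 (0.49 log units; beyond the scatter). The two compounds hold the same atoms, and 4-chlorophenyl and 3-chlorophenyl match in every count, so the place of the chlorine on this ring is the only thing that separates them, and that alone is enough to produce the lowest number of the four compounds. No available measurement bears on why relocating the chlorine has an effect of this size.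

Going by these compounds, it remains open whether the step belongs to chlorine itself or would also appear with a fluoro, a methoxy group, a nitrile or an amine in its place on this ring. Also unresolved is whether 4-chlorophenyl would lower the number to a similar extent on the shared core of compound 2 or compound 3, which carry 3,5-difluorophenyl and 3-fluorophenyl on the sulfonyl sulfur.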